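Swapping the aryloxy acetyl tail for a cyclohexyl ketone

The source may report more compounds than this note shows. Statements on the series, on what has been measured and on what is new or still open speak of the compounds shown alone.

Among the compounds with values here, compound 2 `Nc1nc(N2CCN(C(=O)COc3ccc(Cl)cc3)CC2)c2cc(F)sc2n1` gives the lowest of the two numbers so far, 700 nM in a functional assay on cells (Lymphocyte) (a lower number here means a stronger inhibitor, a higher number a weaker inhibitor), while compound 1 `CCCCc1nc(N2CCN(C(=O)COc3ccc(Cl)cc3)CC2)c2cc(F)sc2n1` gives 1330 nM; the step of a 1.9-fold lower number from compound 1 to compound 2 (0.28 log units; within the scatter) lies within the scatter. Compound 3 `Nc1nc(N2CCN(C(=O)C3CCCCC3)CC2)c2cc(F)sc2n1` differs from compound 2 by cyclohexyl in place of (4-chlorophenoxy)methyl on a carbonyl carbon. Within the data shown here, no measured step touches this part of the molecule; the only known step changed a group on an aromatic carbon, so nothing measured bears directly on this change. The outcome is therefore uncertain, and compound 3 is estimated at 2000 nM (range 500 nM to 8000 nM), meaning an expected step of a 2.9-fold higher number from compound 2 to compound 3 (0.46 log units; beyond the scatter).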

Compound 3, half-maximal inhibitory concentration: > 10000 nM
Compound 3: only a limit was reported; the forecaster's own chance of this, stated with the estimate: 15%; middle value at least 5.0-fold (0.69 log units) away from the limit.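

In this assay compound 3 gives only a limit of the assay, not a number: the limit of > 10000 nM in this assay, at which 1 of the 3 values shown sits.

Within the data shown here, replacing (4-chlorophenoxy)methyl with cyclohexyl on the carbonyl carbon gives an at least 14-fold higher number from compound 2 to compound 3 (1.15 log units; beyond the scatter), whereas the only earlier step lay within the scatter. This position therefore responds clearly, and the aromatic ring, ether oxygen and chlorine together are not interchangeable with a cyclohexyl group.

Which of those three parts counts remains open, as they left together. A phenoxymethyl group without the chlorine, or a benzyl group without the oxygen, would help separate them.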